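Swapping the Aryl Group on a Shared Core: Cytotoxicity Outlook

This account rests on a few compounds, and the source may have more. Where it says the series, first, only, none or still open, it means among the compounds named here.

Compound 1 `Cc1oc(-c2c(F)cccc2F)nc1CN1CCC(C(=O)NCCCN2C[C@H](C)C[C@H](C)C2)CC1`: 32700 nM
Compound 2 `Cc1cccc(Cl)c1-c1nc(CN2CCC(C(=O)NCCCN3CCCC(C)C3)CC2)c(C)o1`: 16400 nM

In an ADME assay on Huh7.5.1 cells (Homo sapiens) for cytotoxicity, read by ATP content, with a stated time of 48 h (a lower number here means that less compound is tolerated, a higher number that more compound is tolerated), compound 1 gives 32700 nM, and compound 2 gives 16400 nM; these two numbers lie within the usual scatter of each other, so neither compound stands apart. Going by the values given here, no step between measured compounds that differ in a single place is available to guide the next move. Compound 3 `COc1ccc(-c2nc(CN3CCC(C(=O)NCCCN4C[C@H](C)C[C@H](C)C4)CC3)c(C)o2)cc1OC` differs from compound 1 in one place: 3,4-dimethoxyphenyl in place of 2,6-difluorophenyl on an aromatic carbon. Among the compounds with values here, with no measured step to lean on, the expected change in this assay is none beyond the scatter. Compound 3 is therefore estimated at 28000 nM, with a likely range from 12000 nM to 65000 nM. That expectation amounts to a step of a 1.2-fold lower number from compound 1 to compound 3 (0.07 log units; within the scatter).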

Compound 3, half-maximal cytotoxic concentration: 57200 nM
Compound 3: middle estimate off by 2.0-fold (0.31 log units), on the low side; low and high end bracket the measured number.
By their numbers in this assay, from the lowest: compounds 2, 1 and 3 (each within the scatter of the next, the first and the last beyond it).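

In this assay, going by these compounds alone, the swap of 2,6-difluorophenyl for 3,4-dimethoxyphenyl gives a 1.7-fold higher number from compound 1 to compound 3 (0.24 log units; within the scatter) and is the first single-place step available. This aromatic carbon of the shared core therefore carries two different aryl groups, one with no hydrogen-bond acceptors and one with two, without a step beyond the scatter. Nothing measured here gives a cause for the numbers. Still open, going by these compounds, is whether a phenyl ring bearing a carboxylic acid or an amine at this place would move the number beyond the scatter.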